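Naphthalenyl Position Swap in a Pyrazoline–Thiazoline Series

This account rests on a few compounds, and the source may have more. Where it says the series, first, only, none or still open, it means among the compounds named here.

Measured compounds:
compound 1, `Fc1ccc(C2=NN(C3=NC(c4ccccc4)CS3)C(c3ccc4ccccc4c3)C2)cc1`, 26500 nM
compound 2, `c1ccc(C2=NN(C3=NC(c4ccccc4)CS3)C(c3ccc4ccccc4c3)C2)cc1`, 17200 nM
compound 3, `Cc1ccc(C2=NN(C3=NC(c4ccccc4)CS3)C(c3cccc4ccccc34)C2)cc1C`, 7250 nM

In a functional assay on HepG2 cells (Homo sapiens) for inhibition, read by CCK-8 assay, with a stated time of 48 h (on this read-out lower numbers stand for stronger inhibition and higher numbers for weaker inhibition), compound 3 gives the lowest number of the three, with compound 2 nearest and compound 1 furthest, both beyond the scatter. Compound 4, `Cc1ccc(C2=NN(C3=NC(c4ccccc4)CS3)C(c3ccc4ccccc4c3)C2)cc1C`, differs from compound 3 by naphthalen-2-yl in place of naphthalen-1-yl on a saturated ring carbon. For the measured compounds named here, the only measured step, a 1.5-fold lower number from compound 1 to compound 2 (0.19 log units; within the scatter), concerns a fluoro on a different ring and does not bear on this change. Going by the values given here, compounds 1 and 2 carry the naphthalen-2-yl group alongside other groups that differ from compound 3, so no pair isolates the swap. Compound 4 is therefore expected to show no step beyond the scatter, a 1.2-fold higher number from compound 3 to compound 4 (0.09 log units; within the scatter). Compound 4 is estimated at 9000 nM, within 3500 nM to 25000 nM.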

Compound 4, half-maximal inhibitory concentration: 7370 nM
Beside the measured number, compound 4's estimate is 1.2-fold (0.09 log units) above it; measured number inside the range.
By their numbers in this assay, from the lowest: compounds 3 and 4 (each within the scatter of the next); then compounds 2 and 1 (each within the scatter of the next).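

Naphthalen-2-yl in place of naphthalen-1-yl on the saturated ring carbon, now isolated in one pair, gives no separation in this assay (a 1.0-fold higher number from compound 3 to compound 4 (0.01 log units; within the scatter)). With naphthalen-2-yl held fixed, 3,4-dimethylphenyl gives a modest step beyond the scatter, both in place of phenyl (a 2.3-fold lower number from compound 2 to compound 4 (0.37 log units; beyond the scatter)) and in place of 4-fluorophenyl (a 3.6-fold lower number from compound 1 to compound 4 (0.56 log units; beyond the scatter)). No evidence is available to explain these results.

From the compounds shown here alone, whether the naphthalenyl swap is equally silent alongside phenyl or 4-fluorophenyl remains open. So does the outcome of placing a group carrying an amine or a carboxylic acid on this saturated ring carbon.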